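Sulfur-to-tellurium exchange carried onto a second core

The source may hold more compounds than are shown below. What is called first, only, known or untested is meant among the compounds shown, and "the series" means these compounds.

Compound 1 `COc1ccc(N(CC(=O)NCCCSc2ccccc2)C(=O)CCSC2=C(C)C(=O)c3ccccc3C2=O)cc1` is the reference; in a functional assay on MCF7 cells (Homo sapiens) for cytotoxicity, read by MTT assay, with a stated time of 24 h (on this read-out higher numbers stand for weaker inhibition and lower numbers for stronger inhibition), compound 1 gives 16000 nM. Compound 2 `COc1ccc(N(CC(=O)NCCC[Te]c2ccccc2)C(=O)CCSC2=C(C)C(=O)c3ccccc3C2=O)cc1` carries a group of 7 heavy atoms (6 carbon, 1 tellurium; one six-membered aromatic ring of carbon only) in place of a group of 7 heavy atoms (6 carbon, 1 sulfur; one six-membered aromatic ring of carbon only), on a saturated chain carbon, three bonds along the chain from an amide-type nitrogen. In this assay compound 2 gives 7000 nM, and the step is a 2.3-fold lower number from compound 1 to compound 2 (0.36 log units; beyond the scatter). Compound 3 `COc1ccc(N(CC(=O)NCCCSc2ccccc2)C(=O)c2ccccc2)cc1` rests on a different core; the difference between the two cores is not broken down here. In this assay compound 3 is reported only as >= 100000 nM, a limit of the assay and not a number, as noted in the limit of >= 100000 nM in this assay, at which 1 of the 3 values shown sits. Compound 4 `COc1ccc(N(CC(=O)NCCC[Te]c2ccccc2)C(=O)c2ccccc2)cc1` differs from compound 3 by a group of 7 heavy atoms (6 carbon, 1 tellurium; one six-membered aromatic ring of carbon only) in place of a group of 7 heavy atoms (6 carbon, 1 sulfur; one six-membered aromatic ring of carbon only), on a saturated chain carbon, three bonds along the chain from an amide-type nitrogen, the same change as from compound 1 to compound 2, at the same place. The expected step is an at least 1.4-fold lower number from compound 3 to compound 4 (0.15 log units; that floor lies within the scatter), taken to mirror the measured one. Resting on a 2.3-fold lower number from compound 1 to compound 2 (0.36 log units; beyond the scatter), compound 4 is expected to give about 70000 nM, estimated between 30000 nM and 200000 nM.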

Compound 4, half-maximal inhibitory concentration: 27000 nM
For compound 4 the middle estimate is 2.6-fold (0.41 log units) above the measured one; measured number below the stated range.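

On the second core the exchange gives an at least 3.7-fold lower number from compound 3 to compound 4 (0.56 log units; beyond the scatter), so in this assay the direction seen on the core of compound 1 carries over to this pair. Compound 3 stands only as >= 100000 nM, a limit of the assay and not a number, and the step on this core is therefore known only as a floor. The pairs show a shared direction on two cores, not a shared size: the same change on two cores in this assay, a 2.3-fold lower number (0.36 log units; beyond the scatter) from compound 1 to compound 2 and an at least 3.7-fold lower number (0.56 log units; beyond the scatter) from compound 3 to compound 4; the limit leaves it open whether they differ

Two cores do not show that the exchange would hold on any other core in the series. Also open, on these data alone, is whether selenium in place of tellurium, or a longer chain at the same place, would go the same way.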